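The source may hold more compounds than are shown below. What is called first, only, known or untested is meant among the compounds shown, and "the series" means these compounds.

Measured so far in a functional assay on A549 cells (Homo sapiens) for antiproliferative activity, read by MTT assay; a higher number here means a weaker inhibitor, a lower number a stronger inhibitor:
- compound 1 `CC1(C)CCc2c(ccc(C(=O)/C=C/c3ccc(OCc4cn(-c5ccc(Br)cc5)nn4)cc3)c2O)O1`: 129000 nM
- compound 2 `Cc1c(-n2cc(COc3ccc(/C=C/C(=O)c4ccc5c(c4O)CCC(C)(C)O5)cc3)nn2)cccc1[N+](=O)[O-]`: "not active" (no number reported)
- compound 3 `CC(=O)c1ccc(-n2cc(COc3ccc(/C=C/C(=O)c4ccc5c(c4O)CCC(C)(C)O5)cc3)nn2)cc1`: 149000 nM

Within the data shown here, only two compounds carry a number, and compound 3, at 149000 nM, stands level with compound 1 within the scatter. Compound 2 gives no number, so no step size can be taken from it, though it does show that the assay can return no number in this series.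

Next is compound 4 `CCc1ccccc1-n1cc(COc2ccc(/C=C/C(=O)c3ccc4c(c3O)CCC(C)(C)O4)cc2)nn1`, where 2-ethylphenyl replaces 4-acetylphenyl on an aromatic nitrogen: 2-ethylphenyl in place of 4-acetylphenyl on an aromatic nitrogen. The shared core and the linking chain stay as they are.

Among the measured compounds shown here, one measured step bears on this, a 1.2-fold higher number from compound 1 to compound 3 (0.06 log units; within the scatter), with acetyl in place of bromo on an aromatic carbon. It lies within the scatter. For the measured compounds named here, it is a different exchange from the one here, so it is only indirect support, and no measured step covers an ethyl group or the swap of the whole aryl group. With nothing larger on record, no step beyond the scatter is expected in this assay, and no direction is favoured with any confidence. The expected change is a 1.2-fold lower number from compound 3 to compound 4 (0.08 log units; within the scatter), which is small.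

For compound 4 the estimated value is 125000 nM, with an expected range of 50000 nM to 280000 nM.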

Compound 4, half-maximal inhibitory concentration: 112000 nM
Compound 4: the middle estimate sits 1.1-fold (0.05 log units) above what was measured, within the range that was stated.
By their numbers in this assay, from the lowest: compounds 4, 1 and 3 (each within the scatter of the next).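

In this assay, 2-ethylphenyl in place of 4-acetylphenyl on the aromatic nitrogen gives a 1.3-fold lower number from compound 3 to compound 4 (0.12 log units; within the scatter), and 2-ethylphenyl in place of 4-bromophenyl gives a 1.2-fold lower number from compound 1 to compound 4 (0.06 log units; within the scatter). The earlier step only exchanged one group for another on a 4-substituted phenyl, whereas these steps also cover a 2-substituted phenyl and the loss of the carbonyl oxygen, the one hydrogen-bond acceptor counted for 4-acetylphenyl, and neither step leaves the scatter. No measurement at hand explains why the numbers stay level across these aryl groups.

Steps involving compound 2 cannot be read, as it has no number, so the nitro and methyl pattern on its phenyl ring cannot be placed against the other aryl groups. On these data alone, it remains open whether any group at this position can move the number beyond the scatter, for example a basic amine or a carboxylic acid on the phenyl ring, or a saturated alkyl chain in place of the whole aryl group.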